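This account rests on a few compounds, and the source may have more. Where it says the series, first, only, none or still open, it means among the compounds named here.

Compound 3 `Cc1ccc(NC(=O)NC(=O)c2ccc(OCc3cccc(F)c3)cc2)cc1-c1nc2ccccc2[nH]1` is the weakest of the three compounds measured here: in a functional assay on MGC-803 cells (Homo sapiens) for inhibition, read by MTT assay, with a stated time of 48 h (a lower number here means a stronger inhibitor, a higher number a weaker inhibitor), compound 3 gives 44800 nM, the highest number of the set. Its nearest neighbour is compound 1 `Cc1ccc(NC(=O)NC(=O)c2ccc(OCc3cccc(Cl)c3)cc2)cc1-c1nc2ccccc2[nH]1`, which in this assay gives 20800 nM, and the step of a 2.2-fold higher number from compound 1 to compound 3 (0.33 log units; beyond the scatter) is fluoro in place of chloro. Compound 2 `Cc1ccc(NC(=O)NC(=O)c2ccc(OCc3ccc(C(F)(F)F)cc3)cc2)cc1-c1nc2ccccc2[nH]1` gives 14900 nM, and the step of a 3.0-fold higher number from compound 2 to compound 3 (0.48 log units; beyond the scatter) is the larger of the two.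

Compound 4 `Cc1ccc(NC(=O)NC(=O)c2ccc(OCc3ccc(F)cc3)cc2)cc1-c1nc2ccccc2[nH]1` differs from compound 3 only in where the fluorine sits: 4-fluorophenyl in place of 3-fluorophenyl on a saturated chain carbon bound to an oxygen on an aromatic ring. For the measured compounds named here, no measured pair moves a fluorine in just this way. The closest guide is the step of a 1.4-fold lower number from compound 1 to compound 2 (0.14 log units; within the scatter), which also shifts a group from the 3-position to the 4-position of that ring while changing the group itself, and it stayed within the scatter. On that basis the step of a 1.5-fold lower number from compound 3 to compound 4 (0.17 log units; within the scatter) is expected to be small, perhaps leaning toward a lower number. Compound 4 is therefore estimated at 30000 nM, within a range from 12000 nM to 75000 nM.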

Compound 4, half-maximal inhibitory concentration: 160 nM
The estimate for compound 4 lay 190-fold (2.27 log units) above the measured number; measured number outside the range, below it.
By their numbers in this assay, from the lowest: compound 4; then compounds 2 and 1 (each within the scatter of the next); then compound 3.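

In this assay, for the compounds shown here, a 280-fold lower number from compound 3 to compound 4 (2.45 log units; beyond the scatter) shows that the same atoms, joined differently, can change the result sharply, so the place of the fluorine on this ring matters far more than the earlier compounds suggested. Neither the fluorine nor the 4-position alone accounts for this: compound 3 also carries fluorine, compound 2 carries its group in the same ring position, and a 93-fold lower number from compound 2 to compound 4 (1.97 log units; beyond the scatter) is a large step, as is a 130-fold lower number from compound 1 to compound 4 (2.11 log units; beyond the scatter) for the change from 3-chlorophenyl to 4-fluorophenyl. Nothing measured here explains why this one arrangement stands apart.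

As far as these compounds go, what remains open is whether a chloro or a methoxy group in place of the fluoro of compound 4 would keep the low number. From the compounds shown here alone, it is also open whether a longer chain between the oxygen and the 4-fluorophenyl ring would keep it.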